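Trimming the Biphenyl: What Removing a Phenyl May Cost

The compounds below may be only part of what the source reports. "The series", "measured", "known", "first", "only" and "open" are said of these compounds alone.

Two members of this series have been measured in an assay on cells for inhibition of Voltage-dependent T-type calcium channel subunit alpha-1H (Homo sapiens), read by patch clamp; a higher number here means a weaker inhibitor, a lower number a stronger inhibitor. Compound 1 `O=C(CC1c2ccccc2N=C(SCCCCCN2CCCC2)N1c1ccccc1)NCc1ccc(F)cc1` gives 57400 nM. Compound 2 `O=C(CC1c2ccccc2N=C(SCCCCCN2CCCC2)N1c1ccc(-c2ccccc2)cc1)NCc1ccccc1` gives 6900 nM, the lower of the two numbers, and the gap between them is beyond the scatter. Compound 3 `O=C(CC1c2ccccc2N=C(SCCCCCN2CCCC2)N1c1ccccc1)NCc1ccccc1` has not yet been measured. It differs from compound 2 by hydrogen in place of phenyl on an aromatic carbon; cut one bond further out, the change reads 4-phenylphenyl to phenyl. Compound 3 thus carries the same group on the ring nitrogen as compound 1 while keeping the benzylamide of compound 2. For the measured compounds named here, no measured pair isolates this change, but compound 1 gives 57400 nM with that same phenyl in place. The expected step is therefore a 5.1-fold higher number from compound 2 to compound 3 (0.71 log units; beyond the scatter), toward a weaker inhibitor and beyond the scatter. Compound 3 is estimated to give 35000 nM in this assay, within a range from 12000 nM to 90000 nM.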

Compound 3, half-maximal inhibitory concentration: 7710 nM
Beside the measured number, compound 3's estimate is 4.5-fold (0.66 log units) above it, and the stated range ends above it.
By their numbers in this assay, from the lowest: compounds 2 and 3 (each within the scatter of the next); then compound 1.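

In this assay, replacing 4-phenylphenyl with phenyl gives a 1.1-fold higher number from compound 2 to compound 3 (0.05 log units; within the scatter), so the outer phenyl, on an aromatic carbon para to a large group, can be removed with no loss these numbers can show. The step that does exceed the scatter lies at the other place, where fluoro gives way to hydrogen, with a 7.4-fold lower number from compound 1 to compound 3 (0.87 log units; beyond the scatter), so the plain phenyl on the ring nitrogen does not by itself hold a compound at the weak value of compound 1. Nothing available bears on why either step comes out as it does.

Going by these compounds, whether a chlorine atom or a methoxy group in place of that fluoro would give the same step remains open, as does the effect of fluoro on the benzylamide of compound 2. Also open, on these data alone, is whether a cyclohexyl or pyridyl group on the ring nitrogen would match phenyl.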